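A few compounds are considered here, and "the series" means these few. Any claim that something is new, unique, unknown or untested is made for them only; others in the source may bear on it.

Compound 1 `COc1ccc2ncc(S(=O)(=O)c3ccc(C)c(Cl)c3)c(N3CCC(C)CC3)c2c1`: 85%
Compound 2 `COc1ccc2ncc(S(=O)(=O)c3ccc(Cl)cc3)c(N3CCC(C)CC3)c2c1`: 91%
Compound 3 `COc1cccc(S(=O)(=O)c2cnc3ccc(OC)cc3c2N2CCC(C)CC2)c1`: 0%

In an assay on isolated protein for displacement of a labelled ligand from metabotropic glutamate receptor 5 (Homo sapiens), with a stated time of 60 min, tested at 1 uM (on this read-out lower numbers stand for less inhibition and higher numbers for more inhibition at the one concentration tested (going by the name of the read-out)), compound 2 gives 91%, the highest of the three numbers. a number 6 percentage points higher from compound 1 to compound 2 (within the scatter), a difference within the scatter, whereas a number 91 percentage points lower from compound 2 to compound 3 (beyond the scatter) and a number 85 percentage points lower from compound 1 to compound 3 (beyond the scatter), both far beyond it.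

Compound 4 `Cc1ccc2ncc(S(=O)(=O)c3ccc(Cl)cc3)c(N3CCC(C)CC3)c2c1` differs from compound 2 on the core: methyl in place of methoxy on an aromatic carbon. Among the compounds with values here, every measured step alters the aryl on the sulfonyl sulfur instead; none touches this position, so the step from compound 2 to compound 4 has no measured precedent, and the expectation rests on the value of compound 2 alone. The account therefore expects a number 11 percentage points lower from compound 2 to compound 4 (beyond the scatter) in this assay, with no direction beyond the scatter foreseeable. Compound 4 is estimated at 80%, within a range from 55% to 95%.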

Compound 4, a percentage reported as inhibition, at one concentration (the size of the read-out at that concentration, not a potency): 79%
Estimate against measurement, compound 4: 1 percentage points above, within the range that was stated.
By their numbers in this assay, from the lowest: compound 3; then compounds 4, 1 and 2 (each within the scatter of the next, the first and the last beyond it).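

Within the data shown here, the position on the core, untouched by the earlier steps, does respond in this assay: methyl in place of methoxy on this aromatic carbon gives a number 12 percentage points lower from compound 2 to compound 4 (beyond the scatter) and still leaves a high number. This step is far smaller than a number 91 percentage points lower from compound 2 to compound 3 (beyond the scatter) at the aryl on the sulfonyl sulfur, so with the 4-chlorophenyl in place, methoxy is not required for substantial inhibition. No measured evidence accounts for the step. The compounds shown leave open how a hydroxyl, an amine or a longer alkoxy chain on this carbon would read.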